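Replacing the ester of compound 3

A few compounds are considered here, and "the series" means these few. Any claim that something is new, unique, unknown or untested is made for them only; others in the source may bear on it.

In a functional assay on HepG2 cells (Homo sapiens), read by MTT assay, with a stated time of 48 h (on this read-out higher numbers stand for weaker inhibition and lower numbers for stronger inhibition), compound 1 `CCn1c(C(=O)NCCCN(C)C)ccc1C(CC)(CC)c1ccc(OCC(O)C(C)(C)C)c(C)c1` gives 360 nM and compound 2 `CCn1c(C(=O)NCCN)ccc1C(CC)(CC)c1ccc(OCC(O)C(C)(C)C)c(C)c1` gives 176 nM, with a 2.0-fold lower number from compound 1 to compound 2 (0.31 log units; beyond the scatter). Compound 3 `C#CC(C)OC(=O)c1ccc(C(CC)(CC)c2ccc(OCC(O)C(C)(C)C)c(C)c2)n1CC` gives > 50000 nM, which is a limit of the assay and not a number. Two measured steps reach it, both large: an at least 130-fold higher number from compound 1 to compound 3 (2.14 log units; beyond the scatter) and an at least 280-fold higher number from compound 2 to compound 3 (2.45 log units; beyond the scatter). Compound 4 `CC[C@@H](C)[C@H](NC(=O)c1ccc(C(CC)(CC)c2ccc(OCC(O)C(C)(C)C)c(C)c2)n1CC)C(=O)O` carries (1-carboxy-2-methylbutyl)amino in place of (1-methylprop-2-yn-1-yl)oxy on a carbonyl carbon, with (1-carboxy-2-methylbutyl)amino in place of (1-methylprop-2-yn-1-yl)oxy on a carbonyl carbon. Like compound 1 and compound 2 it has an amide, but it ends in a carboxy group, so only part of an at least 280-fold higher number from compound 2 to compound 3 (2.45 log units; beyond the scatter) is expected to return. The expected change is an at least 8.3-fold lower number from compound 3 to compound 4 (0.92 log units; beyond the scatter), toward stronger inhibition. For compound 4 the estimate is 6000 nM, with an expected range from 500 nM to 40000 nM.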

Compound 4, half-maximal inhibitory concentration: 127 nM
Estimate against measurement, compound 4: 47-fold (1.67 log units) above; measured number outside the range, below it.
By their numbers in this assay, from the lowest: compounds 4 and 2 (each within the scatter of the next); then compound 1. At a limit, above all of these: compound 3.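

In this assay the group on the carbonyl carbon need not end in an amine: (1-carboxy-2-methylbutyl)amino, which ends in a carboxy group, brings an at least 390-fold lower number from compound 3 to compound 4 (2.59 log units; beyond the scatter). Measured against the two amine-ended amides, the change gives a 1.4-fold lower number from compound 2 to compound 4 (0.14 log units; within the scatter) and a 2.8-fold lower number from compound 1 to compound 4 (0.45 log units; beyond the scatter). The value of compound 3 is a limit and not a number: the limit of > 50000 nM in this assay, at which 1 of the 4 values shown sits.

The compounds shown leave open whether a methyl ester in place of the carboxylic acid, or a plain alkyl chain on the amide nitrogen, would keep this level. They also leave open what the opposite configuration at the two defined stereocentres would give.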